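The source may hold more compounds than are shown below. What is called first, only, known or untested is meant among the compounds shown, and "the series" means these compounds.

Within the data shown here, in a functional assay on HCT-15 cells (Homo sapiens) (on this read-out higher numbers stand for an effect only at larger amounts of compound and lower numbers for an effect already at smaller amounts), compound 1 (`COc1cc(C2OC(c3ccc(N(C)C)cc3)=NN2C(C)=O)cc(OC)c1OC`) gives 0.033 uM and holds the lower of the two numbers so far, while compound 2 (`COc1cc(C2OC(c3ccccc3N(C)C)=NN2C(C)=O)cc(OC)c1OC`) gives 65 uM on the same read-out. Compound 3 (`COc1cc(C2OC(c3ccc(N(C)C)cc3)=NN2C=O)cc(OC)c1OC`) is still unmeasured and differs from compound 1 by hydrogen in place of methyl on a carbonyl carbon in that hydrogen stands in place of methyl on a carbonyl carbon, which turns acetyl into formyl. Among the measured compounds shown here, the single measured step (a 2000-fold higher number from compound 1 to compound 2 (3.29 log units; beyond the scatter)) is large and shows that close relatives can lie far apart. For the measured compounds named here, that step leaves the carbonyl carbon untouched, however, and no measured pair varies the acetyl group, so it sets no size for this change and argues only for a wide range. Compound 1 starts from 0.033 uM at the low end of the numbers, so a modest move to a higher number is expected rather than a further drop. The estimated step is a 3.0-fold higher number from compound 1 to compound 3 (0.48 log units; beyond the scatter) in this assay as a working figure. For compound 3 the estimate is 0.1 uM with 0.02 uM to 1 uM as the expected range.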

Compound 3, concentration for half-maximal effect: 0.096 uM
Compound 3: middle estimate off by 1.0-fold (0.02 log units), on the high side; the range from low to high includes it.
By their numbers in this assay, from the lowest: compound 1; then compound 3; then compound 2.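

In this assay, among these compounds, this is the first look at the carbonyl carbon on the amide-type nitrogen in a ring: hydrogen in place of methyl gives a 2.9-fold higher number from compound 1 to compound 3 (0.46 log units; beyond the scatter) and so counts as a modest step, though one beyond the scatter. Losing that single carbon therefore changes the number far less than exchanging 4-(dimethylamino)phenyl for 2-(dimethylamino)phenyl, the change in a 2000-fold higher number from compound 1 to compound 2 (3.29 log units; beyond the scatter), and compound 3 at 0.096 uM remains at the low end of the numbers in the series, so the methyl of the acetyl group is not needed for an effect at small amounts of compound, while acetyl in compound 1 still holds the lower number of the pair. Nothing at hand explains why acetyl and formyl differ by this amount.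

As far as these compounds go, with only acetyl and formyl at this position, the trend rests on two points, and it remains open whether propionyl, a longer chain, or benzoyl on the same carbonyl carbon would lower the number further or raise it. From the compounds shown here alone, it is equally open whether acetyl to formyl has the same size on the 2-(dimethylamino)phenyl compounds, or whether a carbamate or urea carbonyl would be tolerated here.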